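Swapping the amine on the thiocarbonyl carbon

This account rests on a few compounds, and the source may have more. Where it says the series, first, only, none or still open, it means among the compounds named here.

Measured so far:
- compound 1, `Nc1ccccc1NC(=O)c1ccc(CSC(=S)N2CCc3cc(Cl)ccc32)cc1`, gives 57.7% in a functional assay on MGC-803 cells (Homo sapiens) for antiproliferative activity, read by CCK-8 assay, with a stated time of 72 h, tested at 2 uM; on this read-out lower numbers stand for a weaker effect and higher numbers for a stronger effect at the one concentration tested
- compound 2, `CN1CCN(C(=S)SCc2ccc(C(=O)Nc3ccccc3N)cc2)CC1`, gives 29.6% in this assay

Among these two numbers compound 2 stands lowest, with compound 1 the nearest, a step beyond the scatter. For the measured compounds named here, the only measured step is a number 28.1 percentage points lower from compound 1 to compound 2 (beyond the scatter), a change on the same thiocarbonyl carbon that is altered again here.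

Compound 3, `CN(Cc1cccnc1)C(=S)SCc1ccc(C(=O)Nc2ccccc2N)cc1`, has not yet been measured. It differs from compound 2 as follows: methyl((pyridin-3-yl)methyl)amino in place of 4-methylpiperazin-1-yl on a thiocarbonyl carbon. The entering group is acyclic and carries an aromatic ring, while the leaving group is a saturated ring; the measured step gives no direct guide to such a change, only the hint that this position moves the read-out noticeably.

Given that the one step at this position was modest and that compound 2 sits at the low end, a gain back toward the middle is expected, though with wide uncertainty. For compound 3 the expected step is a number 10.4 percentage points higher from compound 2 to compound 3 (beyond the scatter). Compound 3 is therefore estimated at 40%, in the range 15% to 65%.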

Compound 3, a percentage reported as inhibition, at one concentration (the size of the read-out at that concentration, not a potency): 45.9%
Estimate against measurement, compound 3: 5.9 percentage points below; the range from low to high includes it.
By their numbers in this assay, from the lowest: compound 2; then compound 3; then compound 1.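

In this assay, the step of a number 16.3 percentage points higher from compound 2 to compound 3 (beyond the scatter) shows that the thiocarbonyl carbon accepts an acyclic group carrying an aromatic ring, methyl((pyridin-3-yl)methyl)amino, and that this group gives a stronger effect than the saturated ring of 4-methylpiperazin-1-yl. The same group does not match 5-chloro-2,3-dihydro-1H-indol-1-yl, as the step of a number 11.8 percentage points lower from compound 1 to compound 3 (beyond the scatter) shows. Since both steps lie beyond the usual scatter, the three groups on this carbon now give three distinct levels of effect at the one concentration tested, so the position is more finely graded than a single step could show.

Nothing shown here explains why the read-out follows this order. From the compounds shown here alone, it also remains open which part of the new group matters: a benzyl group in place of the (pyridin-3-yl)methyl part would test the ring nitrogen, while an ethyl group in place of the methyl on the amine nitrogen, or a morpholine ring in place of 4-methylpiperazin-1-yl, would probe the other parts of this position.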